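The compounds below may be only part of what the source reports. "The series", "measured", "known", "first", "only" and "open" are said of these compounds alone.

Working notes on the series. Compound 1 `CCCOc1ccc(NC(=O)CSc2nnc(Cc3nn(C)c(=O)c4ccccc34)n2C)cc1` carries a propoxy anilide on the shared core. In an assay on isolated protein (Mus musculus) for inhibition of IL15-IL15 receptor (Homo sapiens), read by resazurin assay, with stated times of 30 min and 2.5 days (a higher number here means a weaker inhibitor, a lower number a stronger inhibitor), compound 1 gives > 30000 nM, which is a limit of the assay rather than a measured number. Compound 2 `Cn1c(Cc2nn(C)c(=O)c3ccccc23)nnc1SCCCCCCCC(=O)Nc1ccc(O)cc1` has a longer chain ending in a (4-hydroxyphenyl)amino amide; in this assay compound 2 gives > 30000 nM, again a limit. Compound 3 `Cn1c(Cc2nn(C)c(=O)c3ccccc23)nnc1SCCCCCCCC(=O)Oc1ccc(Cl)cc1Cl` replaces that amide with a 2,4-dichlorophenoxy ester; in this assay compound 3 gives 800 nM. For the measured compounds named here, the single measured step, an at least 37-fold lower number from compound 2 to compound 3 (1.57 log units; beyond the scatter), is the only departure from the limit seen so far, and it goes with the amide being exchanged for an ester, not with a change on the aryl ring alone. Compound 1 thus stands at the limit of > 30000 nM in this assay, at which 2 of the 3 values shown sit.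

Compound 4 `Cn1c(Cc2nn(C)c(=O)c3ccccc23)nnc1SCC(=O)Nc1ccc(I)cc1` differs from compound 1 by iodo in place of propoxy on an aromatic carbon. Going by the values given here, no measured step alters a substituent on that ring while keeping the amide, so nothing measured bears directly on this change, and the amide of compound 1 is retained in compound 4. Compound 4 is therefore expected to stay close to the limit, the expected step being an at least 1.5-fold lower number from compound 1 to compound 4 (0.17 log units; that floor lies within the scatter). Compound 4 is estimated at 20000 nM, with a range from 3000 nM to 100000 nM.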

Compound 4, half-maximal inhibitory concentration: "not active" (no number reported)
Compound 4: no number reported; there is nothing to compare the estimate with.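

Compound 4 has no reported number and compound 1 stands at a limit, so no step can be read between them: the limit of > 30000 nM in this assay, at which 2 of the 4 values shown sit. The compounds shown leave open whether any aryl substituent on the anilide alters the result while the amide is kept.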